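The compounds below may be only part of what the source reports. "The series", "measured", "known", "first", "only" and "open" are said of these compounds alone.

Measured so far in an ADME assay on microsomes from liver (Homo sapiens) for metabolic stability; on this read-out lower numbers stand for slow clearance and higher numbers for fast clearance:
Compound 1 `Cc1ccc2[nH]c(C(=O)N[C@H]3CN(S(=O)(=O)c4ccccc4)C[C@@H]3C(=O)N[C@@H]3CCCN(C)C3)cc2c1` gives 50 mL.min-1.g-1 as a number
Compound 2 `Cc1ccc2[nH]c(C(=O)N[C@H]3CN(S(=O)(=O)c4ccccc4)C[C@@H]3C(=O)N[C@H]3CCCNC3)cc2c1` gives < 3 mL.min-1.g-1 as a limit
Compound 3 `O=C(N[C@H]1CN(S(=O)(=O)c2ccccc2)C[C@@H]1C(=O)N[C@H]1CCCNC1)c1cn(C2CC2)cn1` gives < 3 mL.min-1.g-1 as a limit

Compound 3 has no number, only a limit, the one shared by two of the three compounds (the limit of < 3 mL.min-1.g-1 in this assay, at which 2 of the 3 values shown sit). Compound 4 `O=C(N[C@H]1CN(S(=O)(=O)c2ccccc2)C[C@@H]1C(=O)N[C@H]1CCCNC1)c1nnc(-c2ccc(F)cc2)s1` is not yet measured and differs from compound 3 in one place (a group of 12 heavy atoms (8 carbon, 2 nitrogen, 1 fluorine, 1 sulfur; one five-membered aromatic ring with 3 hetero atoms, one six-membered aromatic ring of carbon only) in place of a group of 8 heavy atoms (6 carbon, 2 nitrogen; one three-membered non-aromatic ring of carbon only, one five-membered aromatic ring with 2 hetero atoms), on a carbonyl carbon).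

For the measured compounds named here, two measured steps bear on this change. The only one at the same place is a step that the two limits leave unreadable from compound 2 to compound 3 and it gives no size to carry over. Going by the values given here, the one readable step is an at least 16-fold lower number from compound 1 to compound 2 (1.22 log units; beyond the scatter) and it is large, but it concerns a different place, the group on the amide-type nitrogen. Compound 4 keeps the piperidin-3-yl group of compound 3, so that large step is not repeated here.

Among the compounds with values here, with no sized step at this place, only a modest rise or nothing beyond the scatter is expected in this assay. The estimated step is an at least 1.3-fold higher number from compound 3 to compound 4 (0.12 log units; that floor lies within the scatter) and it is uncertain, as it starts from a limit. For compound 4 the expected value is 4 mL.min-1.g-1 with an estimated range from 2 mL.min-1.g-1 to 15 mL.min-1.g-1 and a fair chance of another limit.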

Compound 4, intrinsic clearance in microsomes: 8.8 mL.min-1.g-1
For compound 4 the middle estimate is 2.2-fold (0.34 log units) below the measured one, within the range that was stated.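

In this assay, the place on the carbonyl carbon now gives a readable step: the group of 12 heavy atoms in compound 4 gives an at least 2.9-fold higher number from compound 3 to compound 4 (0.46 log units; beyond the scatter) and, set against the 5-methyl-1H-indol-2-yl group, gives an at least 2.9-fold higher number from compound 2 to compound 4 (0.46 log units; beyond the scatter) as the second step at this place. Until now this place had shown only limits, so no group on the carbonyl carbon had been seen to move the read-out, whereas compound 4 shows that a change here alone, with the piperidin-3-yl group kept, can lift the number clear of the scatter. Both steps are floors and not full sizes, because each starts from a compound at a limit: the limit of < 3 mL.min-1.g-1 in this assay, at which 2 of the 4 values shown sit.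

On these data alone, the step between the two groups at the limit cannot be read, so the 5-methyl-1H-indol-2-yl and 1-cyclopropyl-1H-imidazol-4-yl groups stay unranked, and the true size of both new steps stays unknown. Also open, as far as these compounds go, is which part of the entering group carries the step, the five-membered aromatic ring with 3 hetero atoms or the fluorine on the six-membered ring, and whether a chlorine, a methoxy group or an amine in place of that fluorine would shift the number.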